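The compounds below may be only part of what the source reports. "The series", "measured", "known", "first", "only" and "open" are said of these compounds alone.

Measured compounds:
compound 1, `Fc1ccc(/C=N/c2sc3c(c2-c2nc4ccccc4s2)CCC3)cc1`, 290 ug/mL
compound 2, `Clc1ccc(/C=N/c2sc3c(c2-c2nc4ccccc4s2)CCC3)cc1`, 342 ug/mL
compound 3, `Fc1ccccc1/C=N/c1sc2c(c1-c1nc3ccccc3s1)CCCC2`, 319 ug/mL

All three were read in an ADME assay on cells (Rhabdomyosarcoma cell, Homo sapiens) for cytotoxicity, read by MTT assay, with a stated time of 72 h; a lower number here means that less compound is tolerated, a higher number that more compound is tolerated. Compound 1 and compound 2 differ by chloro in place of fluoro on an aromatic carbon, and that change gave a 1.2-fold higher number from compound 1 to compound 2 (0.07 log units; within the scatter). Compound 3 carries a different core; the difference between the two cores is not broken down here, and its value sits close to that of compound 2. The not yet measured compound 4, `Clc1ccccc1/C=N/c1sc2c(c1-c1nc3ccccc3s1)CCCC2`, differs from compound 3 by chloro in place of fluoro on an aromatic carbon. Among the compounds with values here, this is the same kind of change as the one from compound 1 to compound 2, but the place differs: para to a large group in the first pair, ortho to a large group in the second. Compound 4 is therefore expected to show a 1.2-fold higher number from compound 3 to compound 4 (0.06 log units; within the scatter) in this assay, resting on the small step seen from compound 1 to compound 2, which lay within the scatter. The estimate for compound 4 is 370 ug/mL, between 250 ug/mL and 550 ug/mL.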

Compound 4, half-maximal cytotoxic concentration: 332 ug/mL
Compound 4: the middle estimate sits 1.1-fold (0.05 log units) above what was measured; the range from low to high includes it.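

In this assay, chloro in place of fluoro on an aromatic carbon gave a 1.0-fold higher number from compound 3 to compound 4 (0.02 log units; within the scatter), so this step on the second core stayed as small as the first. The two steps do not differ from each other: the same change on two cores in this assay, a 1.2-fold higher number (0.07 log units; within the scatter) from compound 1 to compound 2 and a 1.0-fold higher number (0.02 log units; within the scatter) from compound 3 to compound 4, 1.1-fold (0.05 log units) apart, within the scatter of two such steps. This shows that the change left the number within the scatter on both cores, but since neither step rises above the scatter, it does not show a real effect being carried across, nor that other cores would behave alike.

The compounds shown exchange only fluoro and chloro on this aromatic ring. From the compounds shown here alone, what an amine, a methoxy group or a carboxylic acid would do there remains open.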